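The compounds below may be only part of what the source reports. "The series", "measured", "known", "first", "only" and "open" are said of these compounds alone.

Measured compounds:
compound 1, `O=C(CCCCCCc1ccccc1)c1nc(C(=O)C(F)(F)F)co1`: 123 nM
compound 2, `O=C(CCCCCCc1ccccc1)c1nc(Br)co1`: > 10000 nM

In an assay on HEK-293T cells for inhibition of diacylglycerol lipase-alpha (Homo sapiens), read by colorimetric assay (on this read-out higher numbers stand for weaker inhibition and lower numbers for stronger inhibition), compound 1 gives 123 nM. Compound 2 reaches only a limit of the assay and sits at the limit of > 10000 nM in this assay, at which 1 of the 2 values shown sits. Among the compounds with values here, the single measured step, an at least 81-fold higher number from compound 1 to compound 2 (1.91 log units; beyond the scatter), shows how much the loss of the (trifluoromethyl)carbonyl cost. Compound 3, `O=C(CCCCCCc1ccccc1)c1nc(-c2ccccn2)co1`, differs from compound 2 by pyridin-2-yl in place of bromo on an aromatic carbon. Within the data shown here, only that step bears on the change, and it concerns a different group, so no measured step shows a gain from the bromo compound. Compound 3 is therefore expected near 8000 nM, between 800 nM and 50000 nM, an estimated step of an at least 1.2-fold lower number from compound 2 to compound 3 (0.09 log units; that floor lies within the scatter) that may again be only a limit.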

Compound 3, half-maximal inhibitory concentration: > 10000 nM
Compound 3 gave a limit, no number (the forecaster's own chance of this, stated with the estimate: 55%); at least 1.2-fold (0.09 log units) between middle value and limit.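

With pyridin-2-yl on this aromatic carbon, next to the ring nitrogen, the cost of losing the (trifluoromethyl)carbonyl appears again, so it is not confined to bromo: an at least 81-fold higher number from compound 1 to compound 3 (1.91 log units; beyond the scatter) in this assay. Compound 3 also stands at a limit, not a number, so the step between compound 2 and compound 3 cannot be read: the limit of > 10000 nM in this assay, at which 2 of the 3 values shown sit. The added aromatic ring and its hydrogen-bond acceptor bring no inhibition back into the readable range.

From the compounds shown here alone, it remains open whether a methyl ketone, an aldehyde or an ester at this position would keep inhibition. Going by these compounds, how compound 2 and compound 3 truly compare also remains open.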